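The source may hold more compounds than are shown below. What is called first, only, known or untested is meant among the compounds shown, and "the series" means these compounds.

Compound 1 `CC1CCN(c2c(S(=O)(=O)c3ccc(Cl)c(Cl)c3)cnc3ccc(Cl)cc23)CC1` is one of three close analogues that share a core and differ only in the aryl group on the sulfonyl sulfur. In an assay on isolated protein for displacement of a labelled ligand from metabotropic glutamate receptor 5 (Homo sapiens), with a stated time of 60 min, tested at 1 uM (a lower number here means less inhibition, a higher number more inhibition at the concentration tested (going by the name of the read-out)), compound 1 gives 86%, the second highest of the three numbers. Compound 2 `CC1CCN(c2c(S(=O)(=O)c3cc(F)cc(F)c3)cnc3ccc(Cl)cc23)CC1` gives 93%, and the step of a number 7 percentage points higher from compound 1 to compound 2 (within the scatter) lies within the scatter. Compound 3 `CC1CCN(c2c(S(=O)(=O)c3ccc(F)c(F)c3)cnc3ccc(Cl)cc23)CC1` gives 72%; here the step of a number 14 percentage points lower from compound 1 to compound 3 (beyond the scatter) is beyond the scatter, as is a number 21 percentage points lower from compound 2 to compound 3 (beyond the scatter).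

Compound 4 `Cc1ccc2ncc(S(=O)(=O)c3ccc(Cl)c(Cl)c3)c(N3CCC(C)CC3)c2c1` keeps the 3,4-dichlorophenyl of compound 1 on the sulfonyl sulfur and changes the core instead: methyl in place of chloro on an aromatic carbon. For the measured compounds named here, none of the measured steps touches this part of the molecule; all three concern the aryl group on the sulfonyl sulfur, so they set only the range in which the series has so far moved, with no step larger than modest. Going by the values given here, with no direct precedent, compound 4 is expected to stay near compound 1, the step of a number 6 percentage points lower from compound 1 to compound 4 (within the scatter) being the estimate, with wider uncertainty than the measured steps would suggest. Compound 4 is therefore estimated at 80%, between 60% and 95%.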

Compound 4, a percentage reported as inhibition, at one concentration (the size of the read-out at that concentration, not a potency): 82%
Compound 4: the middle estimate sits 2 percentage points below what was measured; measured number inside the range.
By their numbers in this assay, from the lowest: compounds 3, 4, 1 and 2 (each within the scatter of the next, the first and the last beyond it).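

Methyl in place of chloro on this aromatic carbon of the shared core gives a number 4 percentage points lower from compound 1 to compound 4 (within the scatter) in this assay with the 3,4-dichlorophenyl on the sulfonyl sulfur kept. For the compounds shown here, the earlier steps all concerned the aryl group on the sulfonyl sulfur, so this is the first reading at this position, and in this one pair the exchange of these two groups leaves the number within the scatter. Nothing shown here bears on why the number holds under this change.

The compounds shown leave open how a methoxy group, an amine or a carboxylic acid on this carbon would read. They also leave open whether methyl would behave the same with the 3,5-difluorophenyl of compound 2 or the 3,4-difluorophenyl of compound 3 on the sulfonyl sulfur.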